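The source may report more compounds than this note shows. Statements on the series, on what has been measured and on what is new or still open speak of the compounds shown alone.

Among the compounds with values here, compound 2, with the structure `CCOC(=O)Cc1csc(/N=C(\S)N[C@H](C)c2cccc3ccccc23)n1`, is the one measured compound in this set that gives a number: in a functional assay on RBL-2H3 cells (Rattus norvegicus) for inhibition (a higher number here means a weaker inhibitor, a lower number a stronger inhibitor), compound 2 gives 2 nM. The other measured compound, compound 1, with the structure `C[C@H](/N=C(\S)Nc1nc2ccccc2s1)c1cccc2ccccc12`, returns only a limit of the assay in this assay, and that limit for compound 1 is > 100000 nM. Thus compound 2 stands as the only real value, while the other entry is the limit of > 100000 nM in this assay, at which 1 of the 2 values shown sits. Nothing about how compound 1 and compound 2 differ has been followed step by step, as they differ in more than one place; what their two values show is one number and one limit.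

Compound 3, with the structure `CCOC(=O)Cc1csc(/N=C(\S)N[C@@H](C)c2cccc3ccccc23)n1`, has not yet been measured in this assay. The difference from compound 2 is the two compounds have the same atoms and bonds and differ only in configuration as drawn: 1 of 2 stereo elements differ; a stereocentre at a saturated chain carbon is drawn R in compound 2 and S in compound 3. Within the data shown here, no measured step is available to calibrate such a change. The account expects compound 3 to come out weaker than compound 2 in this assay, with an expected step of a 100-fold higher number from compound 2 to compound 3 (2.00 log units; beyond the scatter) that lies beyond the scatter. For compound 3 the estimate in this assay is 200 nM, with an expected range from 10 nM to 5000 nM.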

Compound 3, half-maximal inhibitory concentration: 9 nM
Compound 3: the middle estimate sits 22-fold (1.35 log units) above what was measured; measured number outside the range, below it.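

Turning the stereocentre at the saturated chain carbon from R to S gives a 4.5-fold higher number from compound 2 to compound 3 (0.65 log units; beyond the scatter) in this assay, a modest step, though one that lies beyond the scatter. This shows that the configuration at this carbon registers in the read-out, with the R form of this pair giving the lower number, while compound 3 still gives 9 nM, a value in the low range of its assay. Unlike the comparison of compound 1 with compound 2, which differ in more than one place, this step can be tied to a single change, and the whole of it goes with the stereocentre: the fact that compounds 2 and 3 differ only in the configuration as drawn

The compounds shown leave open whether the same order of R and S holds once the ester side chain on the shared core gives way to a carboxylic acid or an amine. Also open, on these data alone, is whether a longer chain in place of the methyl group at the stereocentre would widen this step, narrow it or reverse it.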